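Isopropylamino to Dimethylamino: Expected Vero Cell Tolerance

A few compounds are considered here, and "the series" means these few. Any claim that something is new, unique, unknown or untested is made for them only; others in the source may bear on it.

Compound 3 `CC(C)Nc1cc(Cl)cc2c(-c3ccnc(NC4CCCC4)n3)c(-c3ccc(F)cc3)nn12` was tested in an ADME assay on Vero cells (Chlorocebus sabaeus) for cytotoxicity; on this read-out higher numbers stand for lower toxicity in this test and lower numbers for higher toxicity in this test. Compound 3 gives > 40000 nM, which is a limit of the assay rather than a number. Compound 1 `Fc1ccc(-c2nn3ccc(Cl)cc3c2-c2ccnc(NC3CCCC3)n2)cc1` likewise gives > 40000 nM, a limit. Compound 2 `Fc1ccc(-c2nn3c(NC4CC4)cc(Cl)cc3c2-c2ccnc(NC3CCCC3)n2)cc1` also gives > 40000 nM, again a limit. The unmeasured compound 4 `CN(C)c1cc(Cl)cc2c(-c3ccnc(NC4CCCC4)n3)c(-c3ccc(F)cc3)nn12` differs from compound 3 by dimethylamino in place of isopropylamino on an aromatic carbon. For the measured compounds named here, the measured steps a step that the two limits leave unreadable from compound 1 to compound 2, a step that the two limits leave unreadable from compound 1 to compound 3 and a step that the two limits leave unreadable from compound 2 to compound 3 each join two limits, so their size cannot be read; the only guidance is the limit of > 40000 nM in this assay, at which 3 of the 3 values shown sit. No measured change in this part of the shared core has shown toxicity within the tested range, so compound 4 is expected to show a step that the limit leaves unreadable from compound 3 to compound 4, none beyond the scatter. In this assay compound 4 is therefore estimated at 60000 nM, between 30000 nM and 150000 nM, most likely reported again only as a limit.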

Compound 4, half-maximal cytotoxic concentration: > 40000 nM
Compound 4 ended at the assay's limit; the forecaster's own chance of this, stated with the estimate: 85%; the middle value is on the limit's open side.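

In this assay compound 4 gives > 40000 nM, a limit and not a number. For the compounds shown here, no step to compound 4 from compound 1, compound 2 or compound 3 can be read. The compounds shown leave open at what concentration any of them harms these cells, and whether their substituents differ at all.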